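The source may hold more compounds than are shown below. What is called first, only, known or untested is meant among the compounds shown, and "the series" means these compounds.

Measured so far:
compound 1 `c1ccc(C[C@H](CCn2cncn2)c2ccccc2)cc1`, 60.9 ug/mL
compound 2 `c1ccc(C[C@@H](CCn2cncn2)c2ccccc2)cc1`, 55.9 ug/mL
compound 3 `Clc1ccc([C@H](CCn2cncn2)Cc2ccccc2)cc1`, 25.7 ug/mL

In an ADME assay on HEp-2 cells (Homo sapiens) for cytotoxicity, read by MTT assay, with a stated time of 3 days (on this read-out higher numbers stand for lower toxicity in this test and lower numbers for higher toxicity in this test), compound 2 stands second highest of the three numbers. Its nearest neighbour is compound 1, with a 1.1-fold lower number from compound 1 to compound 2 (0.04 log units; within the scatter), a pair explained only by the fact that compounds 1 and 2 differ only in the configuration as drawn. Its furthest is compound 3, with a 2.2-fold lower number from compound 2 to compound 3 (0.34 log units; beyond the scatter).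

Compound 4 `c1ccc([C@H](CCn2cncn2)C2CCCCC2)cc1` differs from compound 2 in cyclohexyl in place of benzyl on a saturated chain carbon bound to an aromatic carbon and a saturated chain carbon. Neither measured step changes this part of the core; the closest hint is the modest drop from a 2.2-fold lower number from compound 2 to compound 3 (0.34 log units; beyond the scatter) on altering an aromatic ring, whereas the configurational step a 1.1-fold lower number from compound 1 to compound 2 (0.04 log units; within the scatter) is no guide. The expected step is therefore a 1.2-fold lower number from compound 2 to compound 4 (0.09 log units; within the scatter), modest at most and not clearly beyond the scatter. Compound 4 is estimated at 45 ug/mL, with a range of 20 ug/mL to 100 ug/mL.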

Compound 4, half-maximal cytotoxic concentration: 24.8 ug/mL
For compound 4 the middle estimate is 1.8-fold (0.26 log units) above the measured one; low and high end bracket the measured number.
By their numbers in this assay, from the lowest: compounds 4 and 3 (each within the scatter of the next); then compounds 2 and 1 (each within the scatter of the next).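

In this assay, the substituent on this saturated chain carbon proves not to be neutral: cyclohexyl in place of benzyl gives a 2.3-fold lower number from compound 2 to compound 4 (0.35 log units; beyond the scatter), whereas inversion of the stereocentre gives only a 1.1-fold lower number from compound 1 to compound 2 (0.04 log units; within the scatter). Among these compounds, this is the first measured change at this part of the core, and it lowers the number without adding any hydrogen-bond donor, hydrogen-bond acceptor or net charge. No measured property available here bears on this change.

Open, from the compounds shown here alone, is whether the loss of the aromatic ring or the change from benzyl to a directly attached ring carries the step. Cyclohexylmethyl at this place would separate the two.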